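Swapping the acidic side chain for a plain hydrocarbon branch

This account rests on a few compounds, and the source may have more. Where it says the series, first, only, none or still open, it means among the compounds named here.

Measured compounds:
- compound 1, `N=C(N)NCCC[C@H](NC(=O)CN(c1ncnc2c1ncn2C1CCCCO1)C1CC1)C(=O)OCc1ccccc1`: 34.3%
- compound 2, `O=C(O)CC[C@H](NC(=O)CN(c1nc(Cl)nc2[nH]cnc12)C1CC1)C(=O)O`: 26.8%
- compound 3, `NC(=O)C[C@H](NC(=O)CN(c1ncnc2c1ncn2C1CCCCO1)C1CC1)C(=O)OCc1ccccc1`: 34.5%

All three numbers come from a functional assay on the whole organism (Tail, strain ICR) with Mus musculus as the target, in the tail flick test, with a stated time of 30 min, at a dose of 25 umol/kg by the oral route; on this read-out higher numbers stand for a stronger effect at the one dose given and lower numbers for a weaker effect. Compound 2 differs from compound 1 and from compound 3 by amounts that fall within the usual scatter of this assay, so the three compounds cannot be told apart on these readings.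

Compound 4, `CC[C@H](C)[C@H](NC(=O)CN(c1nc(Cl)nc2[nH]cnc12)C1CC1)C(=O)O`, is not yet measured. Its change from compound 2 is sec-butyl in place of 2-carboxyethyl on a saturated chain carbon bound to an amide-type nitrogen and a carbonyl carbon. Among the compounds with values here, the one measured step that touches a nearby part of the molecule, a number 0.2 percentage points higher from compound 1 to compound 3 (within the scatter), replaced one side group by another on a different core and left this assay unchanged. On that thin basis, the expected step of a number 0.2 percentage points higher from compound 2 to compound 4 (within the scatter) is none beyond the scatter. Compound 4 is therefore estimated at 27%, within 12% to 42%.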

Compound 4, a percentage reported as activity, at one dose (the size of the read-out at that dose, not a potency): 30.3%
Compound 4: the middle estimate sits 3.3 percentage points below what was measured, within the range that was stated.
By their numbers in this assay, from the lowest: compounds 2, 4, 1 and 3 (each within the scatter of the next).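

In this assay, putting sec-butyl in place of 2-carboxyethyl on this saturated chain carbon gives a number 3.5 percentage points higher from compound 2 to compound 4 (within the scatter), so on the shared core these two side chains cannot be told apart. This position therefore accepts a side chain with no hydrogen-bond donors or acceptors and keeps a reading in the same range. Nothing available explains this result. Still open, as far as these compounds go, is whether a primary amine or a longer straight carbon chain at this position would give a reading beyond the scatter.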